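The compounds below may be only part of what the source reports. "The series", "measured", "known", "first", "only" and "open" are said of these compounds alone.

Of the compounds shown here, three sharing one core have been measured in a physicochemical assay for solubility; on this read-out lower numbers stand for lower solubility and higher numbers for higher solubility. Compound 1 `O=C(NC1(C(=O)NO)CCC1)c1ccc(C#Cc2ccccc2)cc1` gives 5000 nM, the highest of the two numbers that were read. Compound 3 `O=C(NC1(C(=O)NO)CCS(=O)(=O)CC1)c1ccc(C#Cc2ccccc2)cc1` gives 2000 nM, a gap from compound 1 that lies beyond the usual scatter. Compound 2 `O=C(NC1(C(=O)NO)CCCCC1)c1ccc(C#Cc2ccccc2)cc1` sits at < 1000 nM, which is a limit of this assay rather than a number (the limit of < 1000 nM in this assay, at which 1 of the 3 values shown sits). Compound 4 `NC[C@H](NC(=O)c1ccc(C#Cc2ccccc2)cc1)C(=O)NO` has not been measured. It differs from compound 1 in one place (a group of 7 heavy atoms (3 carbon, 2 nitrogen, 2 oxygen; no ring) in place of a group of 8 heavy atoms (5 carbon, 1 nitrogen, 2 oxygen; one four-membered non-aromatic ring of carbon only), on an amide-type nitrogen). Going by the values given here, no measured pair follows this kind of change, so the step is judged from the structures alone: an upward step is expected, estimated as a 3.0-fold higher number from compound 1 to compound 4 (0.48 log units; beyond the scatter), beyond the scatter. Compound 4 is therefore expected to give about 15000 nM, with a likely range from 5000 nM to 50000 nM.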

Compound 4, solubility: 13000 nM
The estimate for compound 4 lay 1.2-fold (0.06 log units) above the measured number; low and high end bracket the measured number.
By their numbers in this assay, from the lowest: compound 3; then compound 1; then compound 4. At a limit, below all of these: compound 2.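

Going by these compounds alone, putting a group with no ring in place of the 1-(hydroxycarbamoyl)cyclobutyl group on the amide-type nitrogen gives, in this assay, a 2.6-fold higher number from compound 1 to compound 4 (0.41 log units; beyond the scatter) and is the first step that can be read at this position. It shows that this position can carry a group without a ring and that the number can then rise past that of compound 1. Nothing shown accounts for the size of this step.

As far as these compounds go, whether the rise follows from losing the ring or from the amine in the new group stays open. A carboxylic acid in place of that amine, a longer chain, or the opposite stereocentre could help separate these.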